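The compounds below may be only part of what the source reports. "The series", "measured", "known", "first", "only" and "open" are said of these compounds alone.

Working notes on the series. Compound 1 `CCc1cc(C(C)=O)c(O)cc1OCCCCCC(C)(C)C#N` gives 85% in an assay on isolated protein for inhibition of leukotriene B4 receptor 1 (Homo sapiens), tested at 10 uM; a higher number here means more inhibition at the concentration tested (going by the name of the read-out), a lower number less inhibition. Compound 2 `CCc1cc(C(C)=O)c(O)cc1OCCCCCCCC(C)(C)C#N` gives 66% in this assay, and the step of a number 19 percentage points lower from compound 1 to compound 2 (beyond the scatter) is modest. Compound 3 `CCc1cc(C(C)=O)c(O)cc1OCCCCCC(C)(C)C(=O)O` gives 104% in this assay and stands highest of the three numbers, with the step of a number 19 percentage points higher from compound 1 to compound 3 (beyond the scatter) and the step of a number 38 percentage points higher from compound 2 to compound 3 (beyond the scatter) both beyond the scatter. Compound 4 `CCc1cc(C(C)=O)c(O)cc1OCCCCCC(C)(C)c1nnnn1C` remains to be measured in this assay. The change from compound 3 is 1-methyl-1H-tetrazol-5-yl in place of carboxy on a saturated chain carbon bound to three saturated chain carbons. Within the data shown here, the steps that bear on it are those that reached compound 3 by an exchange of the group on the saturated chain carbon bound to three saturated chain carbons: a number 19 percentage points higher from compound 1 to compound 3 (beyond the scatter), where carboxy replaced cyano, and a number 38 percentage points higher from compound 2 to compound 3 (beyond the scatter). In both the carboxy member gave the higher inhibition and the cyano members sat lower. Among the measured compounds shown here, no measured compound carries 1-methyl-1H-tetrazol-5-yl at this place, so the exchange is untested. The expected step of a number 22 percentage points lower from compound 3 to compound 4 (beyond the scatter) is a modest drop, toward the cyano members rather than below them. Compound 4 is estimated at 82%, between 58% and 102%.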

Compound 4, a percentage reported as inhibition, at one concentration (the size of the read-out at that concentration, not a potency): 99%
The estimate for compound 4 lay 17 percentage points below the measured number; the range from low to high includes it.
By their numbers in this assay, from the lowest: compound 2; then compound 1; then compounds 4 and 3 (each within the scatter of the next).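

In this assay the step of a number 5 percentage points lower from compound 3 to compound 4 (within the scatter) shows that, on a saturated chain carbon bound to three saturated chain carbons, 1-methyl-1H-tetrazol-5-yl can stand in for carboxy without a change beyond the scatter, so the one hydrogen-bond donor counted on carboxy is not needed to keep the number in this pair. The advantage over the cyano members is therefore not confined to carboxy, as the step of a number 14 percentage points higher from compound 1 to compound 4 (beyond the scatter) and the step of a number 33 percentage points higher from compound 2 to compound 4 (beyond the scatter) show, the latter also taking in the longer chain of compound 2. No evidence is available on what lies behind these steps.

On these data alone, whether a primary amide, an amine or a hydroxyl group at this place would keep the number stays open, as does the effect of the longer chain with carboxy or 1-methyl-1H-tetrazol-5-yl. A reading at one concentration also leaves open whether compound 3 and compound 4 differ in potency.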